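The source may hold more compounds than are shown below. What is called first, only, known or untested is meant among the compounds shown, and "the series" means these compounds.

Working notes on the series. All three compounds share one core. For the measured compounds named here, compound 2 `CNC1CC(=O)OC1C(O)C(=O)NC(CC(C)C)C1Cc2cccc(O)c2C(=O)O1` gives 1500 ug/mL in a physicochemical assay for solubility (on this read-out higher numbers stand for higher solubility and lower numbers for lower solubility), and is the only member of the set with a number in this assay rather than a limit. In this assay compound 1 `CCCNC1CC(=O)OC1C(O)C(=O)NC(CC(C)C)C1Cc2cccc(O)c2C(=O)O1` gives > 100000 ug/mL, which is a limit of the assay and not a number. Compound 1 thus sits at the limit of > 100000 ug/mL in this assay, at which 1 of the 2 values shown sits, again a limit and not a number. Going by the values given here, the one measured step is an at least 66-fold lower number from compound 1 to compound 2 (1.82 log units; beyond the scatter), a large fall for removing an ethyl group from the amine. Compound 3 `CCNC1CC(=O)OC1C(O)C(=O)NC(CC(C)C)C1Cc2cccc(O)c2C(=O)O1` has not been measured; it differs from compound 2 by methyl in place of hydrogen on a saturated chain carbon bound to an amine nitrogen, which runs back toward compound 1 but with a smaller group than the ethyl that was removed. The measured step bears on it directly, so a rise in solubility beyond the scatter is expected, probably part of the way back rather than all of it. The expected step is a 6.7-fold higher number from compound 2 to compound 3 (0.82 log units; beyond the scatter). Compound 3 is therefore estimated at 10000 ug/mL, in the range 3000 ug/mL to 40000 ug/mL.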

Compound 3, solubility: > 100000 ug/mL
Compound 3: a limit, no number; the forecaster's own chance of this, stated with the estimate: 15%; at least 10-fold (1.00 log units) between middle value and limit.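

In this assay, for the compounds shown here, the change from methylamino to ethylamino is an at least 66-fold higher number from compound 2 to compound 3 (1.82 log units; beyond the scatter), and this is the first reading of a single methyl at this position. The earlier step removed an ethyl group from compound 1, so it could not show whether a smaller addition to compound 2 would be enough; the methyl alone already reaches the limit shared by compound 1 and compound 3: the limit of > 100000 ug/mL in this assay, at which 2 of the 3 values shown sit. Going by these compounds, both of those values are limits and not numbers, so the step between these two compounds cannot be read, and any order between methyl and ethyl at this position stays unknown.

On these data alone, how far compound 1 and compound 3 lie past the limit remains open. So does what a branched chain such as isopropyl, or a dimethylamino group, would give in this assay.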